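The compounds below may be only part of what the source reports. "The series", "measured", "known", "first", "only" and "open" are said of these compounds alone.

Compound 2 `CNC1=CC(=O)c2cc(C)ncc2C1=O` stands at the lower of the two numbers recorded so far in a functional assay on cells (Homo sapiens) for cytotoxicity, read by propidium iodide staining, with a stated time of 4 days (a higher number here means a weaker inhibitor, a lower number a stronger inhibitor), where compound 2 gives 4930 nM. Going by the values given here, its only neighbour, compound 1 `CNC1=CC(=O)c2c(cnc(C)c2C)C1=O`, gives 26000 nM in this assay, and the single known step, a 5.3-fold lower number from compound 1 to compound 2 (0.72 log units; beyond the scatter), is hydrogen in place of methyl on an aromatic carbon.

Compound 3 `Cc1cc2c(cn1)C(=O)C(NCl)=CC2=O` differs from compound 2 by chloro in place of methyl on an amine nitrogen. Among the compounds with values here, no measured step touches the amine nitrogen or exchanges a methyl for a chloro anywhere, so the one step from compound 1 to compound 2, modest as it was and concerning an aromatic carbon, does not bear directly on this change. The data give no ground to expect a shift in either direction beyond the scatter, and the uncertainty is wide.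

The estimate for compound 3 in this assay is therefore 5000 nM, with a range from 1000 nM to 25000 nM. That estimate corresponds to an expected step of a 1.0-fold higher number from compound 2 to compound 3 (0.01 log units; within the scatter), which is judged no more than the scatter of the measurement.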

Compound 3, half-maximal inhibitory concentration: 1810 nM
Beside the measured number, compound 3's estimate is 2.8-fold (0.44 log units) above it, within the range that was stated.
By their numbers in this assay, from the lowest: compound 3; then compound 2; then compound 1.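

In this assay, chloro in place of methyl on the amine nitrogen gives a 2.7-fold lower number from compound 2 to compound 3 (0.44 log units; beyond the scatter), so the number responds to a change at this nitrogen as well as to one on an aromatic carbon. The earlier compounds shown here showed only the aromatic carbon change, a 5.3-fold lower number from compound 1 to compound 2 (0.72 log units; beyond the scatter), and the new step at a different place runs in the same direction, towards a stronger inhibitor. No measurement at hand bears on why exchanging methyl for chloro at this position has this effect.

Going by these compounds, whether other groups on the amine nitrogen, such as bromo, a longer chain or a plain hydrogen, would lower the number further or raise it again stays open, as does whether chloro there would give a step of similar size on the core of compound 1, with its additional methyl on an aromatic carbon. A single step at this position marks a direction for this one pair of compounds and does not yet establish a trend.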